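Chain extension on the amide arm: compound 2 to compound 4

A few compounds are considered here, and "the series" means these few. Any claim that something is new, unique, unknown or untested is made for them only; others in the source may bear on it.

Three compounds of the series carry a number in an assay on HEK293 cells for displacement of a labelled ligand from NPC1-like intracellular cholesterol transporter 1 (Homo sapiens); on this read-out lower numbers stand for stronger inhibition and higher numbers for weaker inhibition. Compound 1 `CC(C)(C)OC(=O)NCC1CCCN(C(=O)CN2CN(c3ccccc3)C3(CCN(C(=O)c4ccc(C5CCCCC5)cc4)CC3)C2=O)C1` gives 3800 nM. Compound 2 `CC(C)(C)c1ccc(C(=O)N2CCC3(CC2)C(=O)N(CC(=O)NCCO)CN3c2ccccc2)cc1` gives 1000 nM. Compound 3 `O=C(CN1CN(c2ccccc2)C2(CCN(C(=O)c3ccc(C4CCCCC4)cc3)CC2)C1=O)NCCO` gives 2000 nM. Compound 2 thus gives the lowest of the three numbers, though the gap to compound 3 is small: a 2.0-fold higher number from compound 2 to compound 3 (0.30 log units; within the scatter) is within the scatter. Among the compounds with values here, compound 1 and compound 2 differ in more than one place and no step is computed for them; their two values simply stand apart.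

Compound 4 `CC(C)(C)c1ccc(C(=O)N2CCC3(CC2)C(=O)N(CC(=O)NCCCCCNS(C)(=O)=O)CN3c2ccccc2)cc1` is not yet measured. It differs from compound 2 by 3-(methanesulfonamido)propyl in place of hydroxy on a saturated chain carbon, two bonds along the chain from an amide-type nitrogen. Within the data shown here, the single computed step, a 2.0-fold higher number from compound 2 to compound 3 (0.30 log units; within the scatter), concerns the tert-butyl to cyclohexyl exchange on the aromatic carbon and does not touch the amide arm, so no measured step bears directly on this change. The values of compound 1 and compound 3, which carry different amide arms, lie close to each other and give no sign of a large effect from this arm.

On that basis no step beyond the scatter is expected; the estimated step is a 1.5-fold higher number from compound 2 to compound 4 (0.18 log units; within the scatter), with wide uncertainty. Compound 4 is therefore expected at 1500 nM, within 500 nM to 5000 nM.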

Compound 4, half-maximal inhibitory concentration: 5500 nM
Compound 4: middle estimate off by 3.7-fold (0.56 log units), on the low side; the whole stated range lies below it.
By their numbers in this assay, from the lowest: compounds 2, 3, 1 and 4 (each within the scatter of the next, the first and the last beyond it).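

In this assay, within the data shown here, the amide arm gives the first single change with a step beyond the scatter: a 5.5-fold higher number from compound 2 to compound 4 (0.74 log units; beyond the scatter), with 3-(methanesulfonamido)propyl in place of hydroxy on a saturated chain carbon, two bonds along the chain from an amide-type nitrogen. Among these compounds, the only earlier step, a 2.0-fold higher number from compound 2 to compound 3 (0.30 log units; within the scatter), lay within the scatter and concerned an exchange on an aromatic carbon, leaving this position untested; the position now proves responsive, and this exchange moves toward weaker inhibition. No measurement at hand accounts for the step.

Among the compounds shown here, the single step cannot separate the effect of chain length from that of the methanesulfonamido group, since 2-hydroxyethyl and 5-(methanesulfonamido)pentyl differ in both. Going by these compounds, a 5-hydroxypentyl or 5-aminopentyl arm on the core of compound 2 would address that question, and whether the step carries over to the cyclohexyl partner, compound 3, also remains open.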